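Adding a Hydroxypropyl Chain to a Weakly Active Amidine

The source may hold more compounds than are shown below. What is called first, only, known or untested is meant among the compounds shown, and "the series" means these compounds.

Compound 1 `CC1(C)CC(N)=Nc2ccc(Cl)cc21` was tested in a functional assay on MDA-MB-231 cells (Homo sapiens) for cytotoxicity, read by MTT assay, with a stated time of 72 h, tested at 5 uM, in the absence of a further agent (a lower number here means a stronger effect, a higher number a weaker effect of the compound at the concentration tested), and gives 81%, the higher of the two numbers recorded, so its effect at this concentration is weak. Compound 2 `CCN(CC)CCCNC1=Nc2ccc(Cl)cc2C(C)(C)C1` gives 36.1% in this assay, a gap beyond the usual scatter. Compound 3 `CC1(C)CC(NCCCO)=Nc2ccc(Cl)cc21` has not yet been measured; it differs from compound 1 by 3-hydroxypropyl in place of hydrogen on an amine nitrogen. Among the measured compounds shown here, no directly comparable measured pair exists, so the expected step rests on the lower number of compound 2: a move toward a stronger effect, expected as a number 26 percentage points lower from compound 1 to compound 3 (beyond the scatter). Compound 3 is estimated at 55%, within a range of 35% to 78%.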

Compound 3, a percentage reported as activity, at one concentration (the size of the read-out at that concentration, not a potency): 84.2%
The estimate for compound 3 lay 29.2 percentage points below the measured number; measured number outside the range, above it.
By their numbers in this assay, from the lowest: compound 2; then compounds 1 and 3 (each within the scatter of the next).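

In this assay, 3-hydroxypropyl in place of hydrogen on this amine nitrogen does not separate the two compounds (a number 3.2 percentage points higher from compound 1 to compound 3 (within the scatter)). A chain on this nitrogen is therefore not enough on its own to give a stronger effect; what stands at the chain's end counts, as hydroxy in place of diethylamino shows (a number 48.1 percentage points higher from compound 2 to compound 3 (beyond the scatter)). (No measurement shown here explains this result).

Open, as far as these compounds go, is whether another amine at the chain's end, such as dimethylamino or morpholine, would match compound 2. Also open, from the compounds shown here alone, is whether a shorter or longer chain carrying diethylamino would do so.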